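Swapping an indole for an acetylphenyl on the shared core

This account rests on a few compounds, and the source may have more. Where it says the series, first, only, none or still open, it means among the compounds named here.

Of the compounds shown here, two with a shared core have been measured for how strongly they slow the growth of a breast cancer cell line. Compound 1 `COc1cc(-c2ccnc3cc(-c4c[nH]c5ccccc45)nn23)cc(OC)c1OC` gives 85 nM in a functional assay on MCF7 cells (Homo sapiens) for inhibition, read by CCK-8 assay, with a stated time of 48 h; a lower number here means a stronger inhibitor, a higher number a weaker inhibitor. Within the data shown here, compound 2 `COc1cc(-c2ccnc3cc(-c4ccc5cc[nH]c5c4)nn23)cc(OC)c1OC` gives 23 nM in this assay; the only change between them, 1H-indol-6-yl in place of 1H-indol-3-yl on an aromatic carbon, brings a 3.7-fold lower number from compound 1 to compound 2 (0.57 log units; beyond the scatter). Compound 1 therefore stands as the higher of the two numbers, its nearest neighbour being compound 2.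

Compound 3 `COc1cc(-c2ccnc3cc(-c4ccc(C(C)=O)cc4)nn23)cc(OC)c1OC` is not yet measured. It differs from compound 1 as follows: 4-acetylphenyl in place of 1H-indol-3-yl on an aromatic carbon. Among the measured compounds shown here, the one measured step, from compound 1 to compound 2, moves the indole to another attachment point but keeps an indole; it does not show what happens when the indole is exchanged for a group with a carbonyl and no hydrogen-bond donor. For the measured compounds named here, no measured step bears directly on this change, so the expectation rests on compound 1 alone. The estimate is that compound 3 gives 150 nM in this assay, in a range from 40 nM to 600 nM, meaning an expected step of a 1.8-fold higher number from compound 1 to compound 3 (0.25 log units; within the scatter).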

Compound 3, half-maximal inhibitory concentration: 5230 nM
The estimate for compound 3 lay 35-fold (1.54 log units) below the measured number, and the stated range ends below it.
By their numbers in this assay, from the lowest: compound 2; then compound 1; then compound 3.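

In this assay, replacing the indole with 4-acetylphenyl on this aromatic carbon gives a 62-fold higher number from compound 1 to compound 3 (1.79 log units; beyond the scatter), and the same replacement starting from the other indole gives a 230-fold higher number from compound 2 to compound 3 (2.36 log units; beyond the scatter). Both steps are far larger than the shift seen on changing the indole's attachment point, a 3.7-fold lower number from compound 1 to compound 2 (0.57 log units; beyond the scatter), so at this position the choice between an indole and 4-acetylphenyl matters much more than how the indole is attached, even though the two groups have the same heavy-atom count. Compound 3 is the weakest of the three inhibitors in this assay, and nothing shown here offers a measured explanation for the size of this loss.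

The swap changes several things at once: the hydrogen-bond donor and the five-membered ring leave, while an acetyl group with its carbonyl enters, and the compounds shown cannot say which of these changes matters. A plain phenyl ring, a 4-aminophenyl or a 4-hydroxyphenyl at the same place would help separate the loss of the indole from the presence of the acetyl group.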